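The compounds below may be only part of what the source reports. "The series", "measured", "known", "first", "only" and "open" are said of these compounds alone.

Measured so far:
compound 1, `COc1ccc(OC)c(-c2cc(-c3ccccc3)nn2-c2ccc(S(=O)(=O)NC(C)=O)cc2)c1`, gives 42600 nM;
compound 2, `NS(=O)(=O)c1ccc(-n2nc(-c3ccccc3)cc2-c2cc(O)ccc2O)cc1`, gives 100000 nM.

Both numbers come from a functional assay on cells (Cancer cell lines, Homo sapiens) for cytotoxicity, read by sulforhodamine B assay, with a stated time of 48 h; a higher number here means a weaker inhibitor of growth, a lower number a stronger inhibitor of growth. Compound 2 stands at the higher of the two values; compound 1, whose structure differs from it in more than one place, sits at a lower number, and the gap between them lies beyond the usual scatter of this kind of measurement. Nothing more can be read from that pair, since no single change separates them.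

The next compound, compound 3, `CC(=O)NS(=O)(=O)c1ccc(-n2nc(-c3ccccc3)cc2-c2cc(O)ccc2O)cc1`, follows from compound 2 by one change: acetyl in place of hydrogen on a sulfonamide nitrogen. For the measured compounds named here, no measured pair shows this exact step, so its effect is not known from the data. Going by the values given here, the only guide is that compound 1, which also carries the acetylsulfamoyl group, gives 42600 nM in this assay. On that basis a modest move toward a lower number is expected for compound 3, though a step that stays within the scatter remains quite possible: the expected step is a 1.7-fold lower number from compound 2 to compound 3 (0.22 log units; within the scatter). Compound 3 is therefore estimated at 60000 nM, within a range of 25000 nM to 100000 nM.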

Compound 3, concentration for total growth inhibition: 100000 nM
Compound 3: middle estimate off by 1.7-fold (0.22 log units), on the low side; low and high end bracket the measured number.
By their numbers in this assay, from the lowest: compound 1; then compounds 2 and 3 (each within the scatter of the next).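

On the sulfonamide nitrogen, with the 2,5-dihydroxyphenyl group held in place, acetyl in place of hydrogen gives no change at the digits printed from compound 2 to compound 3 (within the scatter) and so separates the sulfamoyl and acetylsulfamoyl forms by nothing that this measurement can resolve. With the acetylsulfamoyl group held in place, 2,5-dihydroxyphenyl in place of 2,5-dimethoxyphenyl on an aromatic carbon gives a 2.3-fold higher number from compound 1 to compound 3 (0.37 log units; beyond the scatter) and is a modest step, which places the gap seen earlier between compound 1 and compound 2 with the change on the aromatic carbon rather than with the acetyl group, at least among these three compounds. No measurement shown here accounts for either step.

The compounds shown leave open whether the sulfamoyl and acetylsulfamoyl forms would also stand level alongside 2,5-dimethoxyphenyl, since the acetyl step has been read only alongside 2,5-dihydroxyphenyl. They also leave open how a longer acyl chain such as butanoyl, or a carboxylic acid or an amine carried on the sulfonamide nitrogen, would read in this series, and whether a single methoxy group on the aromatic ring would fall nearer to compound 1 or to compound 3.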